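From 2-methoxyethynyl to hept-1-en-1-yl

A few compounds are considered here, and "the series" means these few. Any claim that something is new, unique, unknown or untested is made for them only; others in the source may bear on it.

Measured in a functional assay on A-431 cells (Homo sapiens) for inhibition; on this read-out higher numbers stand for weaker inhibition and lower numbers for stronger inhibition:
Compound 1 `CCCCCCC[C@@]1(C)O[C@@H]2OC(=O)N(C(=O)CCl)[C@@H]2CC1=O`: 78000 nM
Compound 2 `COC#C[C@@]1(C)O[C@@H]2OC(=O)N(C(=O)CCl)[C@@H]2CC1=O`: 64000 nM

Going by the values given here, compound 2 sits within the scatter of compound 1, the only other compound measured on this core. Compound 3 `CCCCC/C=C/[C@@]1(C)O[C@@H]2OC(=O)N(C(=O)CCl)[C@@H]2CC1=O` has not yet been measured. It carries hept-1-en-1-yl in place of 2-methoxyethynyl on a saturated ring carbon, and the difference counts as hept-1-en-1-yl in place of 2-methoxyethynyl on a saturated ring carbon. Among the compounds with values here, one measured step bears on this change: a 1.2-fold lower number from compound 1 to compound 2 (0.09 log units; within the scatter), where 2-methoxyethynyl took the place of heptyl on that same saturated ring carbon. That exchange of a heptyl chain stayed within the scatter, so the present one is expected to do the same. The expected change is a 1.1-fold higher number from compound 2 to compound 3 (0.04 log units; within the scatter) in this assay, with no shift beyond the scatter. Compound 3 is estimated at 70000 nM, with an expected range from 35000 nM to 140000 nM for repeated measurements.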

Compound 3, half-maximal inhibitory concentration: 81000 nM
The estimate for compound 3 lay 1.2-fold (0.06 log units) below the measured number; the measured number falls inside the stated range.
By their numbers in this assay, from the lowest: compounds 2, 1 and 3 (each within the scatter of the next).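

In this assay, hept-1-en-1-yl in place of 2-methoxyethynyl on this saturated ring carbon gives a 1.3-fold higher number from compound 2 to compound 3 (0.10 log units; within the scatter) and hept-1-en-1-yl in place of heptyl gives a 1.0-fold higher number from compound 1 to compound 3 (0.02 log units; within the scatter) on the same carbon. With a third group in place, all three pairs of compounds now lie within the scatter, and this holds for compound 3 against both a chain with a triple bond and oxygen and a saturated chain of the same length, so the double bond of hept-1-en-1-yl brings no shift here. Nothing at hand accounts for this lack of change.

All three groups are uncharged open chains, so the compounds shown leave open whether an amine, a carboxylic acid or a phenyl ring on this carbon would move the number beyond the scatter. They also leave open what a change elsewhere on the shared core, such as at the chloroacetyl group, would do.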